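A limit at the start: compound 3 to compound 4

The compounds below may be only part of what the source reports. "The series", "measured", "known", "first", "only" and "open" are said of these compounds alone.

In a physicochemical assay for lipophilicity, at pH 7.4 (on this read-out lower numbers stand for lower lipophilicity and higher numbers for higher lipophilicity), compound 1 `Cc1cc(C(=O)Nc2ccccn2)nn1Cc1cc(Cl)ccc1OCc1ccccc1` gives > 3.7, which is a limit and not a number. Compound 2 `Cc1cc(C(=O)NCc2ccccn2)nn1Cc1cc(Cl)ccc1OCc1ccccc1` also gives a limit, > 3.7. Compound 3 `Cc1cc(C(=O)NCc2cccnc2)nn1Cc1cc(Cl)ccc1OCc1ccccc1` gives a limit too, > 3.7. The measurements so far therefore offer only (the limit of > 3.7 in this assay, at which 3 of the 3 values shown sit).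

Compound 4 `Cc1cc(NC(=O)C2CCCO2)nn1Cc1cc(Cl)ccc1OCc1ccccc1` carries ((oxolan-2-yl)carbonyl)amino in place of ((pyridin-3-yl)methyl)carbamoyl on an aromatic carbon of the shared core: ((oxolan-2-yl)carbonyl)amino in place of ((pyridin-3-yl)methyl)carbamoyl on an aromatic carbon.

The measured steps that bear on this change are those around the amide-type nitrogen: a step that the two limits leave unreadable from compound 1 to compound 2, a step that the two limits leave unreadable from compound 1 to compound 3 and a step that the two limits leave unreadable from compound 2 to compound 3. None of them has a readable size, so they give neither a size nor a direction to carry over. For the measured compounds named here, the only anchor is compound 3 with its limit > 3.7, so no step beyond the scatter is expected in this assay. The estimated change is a step that the limit leaves unreadable from compound 3 to compound 4. For compound 4 the expected value is 3.8, with an estimated range from 3.3 to 4.3.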

Compound 4, distribution coefficient: > 3.7
Compound 4: only a limit was reported (the forecaster's own chance of this, stated with the estimate: 55%); the middle value does not contradict the limit.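

Compound 4 gives only a limit in this assay, as do compound 1, compound 2 and compound 3, so no step involving compound 4 can be read: the limit of > 3.7 in this assay, at which 4 of the 4 values shown sit.

From the compounds shown here alone, the true values of all four compounds stay open, as does whether placing ((oxolan-2-yl)carbonyl)amino in place of ((pyridin-3-yl)methyl)carbamoyl shifts the read-out at all.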